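Fixing One Stereocentre in Compound 3

The source may hold more compounds than are shown below. What is called first, only, known or untested is meant among the compounds shown, and "the series" means these compounds.

Compound 1 `CCCCOc1nccnc1C1CN2CCC1CC2` gives 24100000 nM in a functional assay on A9L-m1 cells with A9 (Mus musculus) as the target; on this read-out lower numbers stand for an effect already at smaller amounts and higher numbers for an effect only at larger amounts of compound.
Compound 2 `CCCCCCOc1nccnc1C1CN2CCC1CC2` gives 520000 nM in this assay.

Among the compounds with values here, compound 2 holds the lower of the two numbers measured so far, and the gap to the other compound lies beyond the scatter. The next compound to be tested is compound 3 `CCCCCCOc1nccnc1[C@@H]1CN2CCC1CC2`. Its structure differs from that of compound 2 only in how it is drawn: the two compounds have the same atoms and bonds; at least one stereo element is drawn with a configuration in one of them and without one in the other: 1 of 3 stereo elements differ; a stereocentre at a saturated ring carbon is drawn without a configuration in compound 2 and S in compound 3. The atoms and bonds stay the same, and a stereocentre at a saturated ring carbon that has no configuration in compound 2 is S in compound 3.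

Within the data shown here, only one measured step is available, a 46-fold lower number from compound 1 to compound 2 (1.67 log units; beyond the scatter). It is large, but it comes from an ethyl in place of hydrogen on a saturated chain carbon and involves no change at a stereocentre. It therefore bears only indirectly on this comparison, and the data give no measured size for a change of this kind. No step beyond the scatter is expected in this assay, and no direction can be firmly assigned. The estimated step is a 1.2-fold lower number from compound 2 to compound 3 (0.06 log units; within the scatter). For compound 3 the estimated value is 450000 nM, with an expected range from 180000 nM to 1300000 nM.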

Compound 3, half-maximal effective concentration: 360000 nM
The estimate for compound 3 lay 1.3-fold (0.10 log units) above the measured number; low and high end bracket the measured number.
By their numbers in this assay, from the lowest: compounds 3 and 2 (each within the scatter of the next); then compound 1.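

In this assay, within the data shown here, this is the first measured change at the stereocentre on the saturated ring carbon, and it gives a 1.4-fold lower number from compound 2 to compound 3 (0.16 log units; within the scatter). The earlier step, a 46-fold lower number from compound 1 to compound 2 (1.67 log units; beyond the scatter), came from the chain and lay beyond the scatter, whereas the stereocentre change does not separate the two compounds: compound 3, with the S configuration drawn, gives 360000 nM and cannot be told apart from compound 2 in this read-out. The step cannot be taken as a comparison of two defined stereoisomers, because it rests on a difference in how the structures are drawn: the fact that one of compounds 2 and 3 is drawn with a defined configuration and the other without, at the place where they differ

The compounds shown leave open how a compound drawn with the R configuration at this carbon would read, and so whether this stereocentre matters at all in this assay. They also leave open whether the large chain step would continue with a longer chain, and how the shared core would respond to an amine in place of the oxygen on the aromatic ring.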